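Pyrazole chalcones: from methoxyphenyl back to a dihalophenyl

This account rests on a few compounds, and the source may have more. Where it says the series, first, only, none or still open, it means among the compounds named here.

Measured so far in a functional assay on CAKI-1 cells (Homo sapiens) for cytotoxicity, read by sulforhodamine B assay, with a stated time of 48 h, tested at 10 uM; on this read-out higher numbers stand for a weaker effect at the one concentration tested and lower numbers for a stronger effect:
- compound 1 `COc1cc(-c2cc(/C=C/C(=O)c3ccc(Cl)c(Cl)c3)[nH]n2)cc(OC)c1OC`: 62%
- compound 2 `COc1ccc(C(=O)/C=C/c2cc(-c3cc(OC)c(OC)c(OC)c3)n[nH]2)cc1OC`: -33%
- compound 3 `COc1ccc(C(=O)/C=C/c2cc(-c3cc(OC)c(OC)c(OC)c3)n[nH]2)cc1`: -17%

Compound 3 holds the second highest of the three numbers in this assay. Its nearest neighbour is compound 2, and the step of a number 16 percentage points higher from compound 2 to compound 3 (beyond the scatter) is modest. Its furthest neighbour is compound 1, and the step of a number 79 percentage points lower from compound 1 to compound 3 (beyond the scatter) is large.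

Compound 4 `COc1cc(-c2cc(/C=C/C(=O)c3ccc(F)c(F)c3)[nH]n2)cc(OC)c1OC` is not yet measured. It differs from compound 3 in one place: 3,4-difluorophenyl in place of 4-methoxyphenyl on a carbonyl carbon.

Within the data shown here, two measured steps bear on this change, both swapping the group on the carbonyl carbon. The step of a number 79 percentage points lower from compound 1 to compound 3 (beyond the scatter) and the step of a number 95 percentage points lower from compound 1 to compound 2 (beyond the scatter) show that replacing 3,4-dichlorophenyl by a methoxy-bearing phenyl lowered the number by a large amount. Compound 4 goes the other way, putting a 3,4-difluorophenyl where compound 3 has 4-methoxyphenyl. Among the measured compounds shown here, no measured step compares 3,4-difluorophenyl with 3,4-dichlorophenyl, so the size is uncertain, but a large rise toward compound 1 is expected. Compound 4 is therefore estimated at 30%, in a range from -10% to 70%, which means an expected step of a number 47 percentage points higher from compound 3 to compound 4 (beyond the scatter).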

Compound 4, a percentage reported as activity, at one concentration (the size of the read-out at that concentration, not a potency): 12%
Beside the measured number, compound 4's estimate is 18 percentage points above it, within the range that was stated.
By their numbers in this assay, from the lowest: compound 2; then compound 3; then compound 4; then compound 1.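

Placing a 3,4-difluorophenyl on the carbonyl carbon gives a number 29 percentage points higher from compound 3 to compound 4 (beyond the scatter) and a number 45 percentage points higher from compound 2 to compound 4 (beyond the scatter) in this assay, so the fluorinated ring sits above both methoxy-bearing rings on this read-out. The two halogens do not behave alike here, however: a number 50 percentage points lower from compound 1 to compound 4 (beyond the scatter) shows that the 3,4-difluorophenyl and 3,4-dichlorophenyl rings can give numbers far apart, a contrast that the earlier comparison of 3,4-dichlorophenyl with the methoxy-bearing rings could not reveal. The outcome at this position therefore depends on which halogen is present, not only on whether the ring carries halogens or methoxy groups, although no evidence is available to explain this difference.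

The compounds shown leave open where a 3,4-dibromophenyl, a phenyl with a single chlorine, or a phenyl carrying an amine or a carboxylic acid would fall in this order. They also leave open whether the same order of these rings would hold if the 3,4,5-trimethoxyphenyl group of the shared core were replaced by an unsubstituted phenyl.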